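Swapping the benzylamide of compound 3 for a morpholine amide

A few compounds are considered here, and "the series" means these few. Any claim that something is new, unique, unknown or untested is made for them only; others in the source may bear on it.

The three measured compounds share one core and differ only at the amide end. Compound 1 `CNC(=O)CC1CCc2cc(OC)c(OC)cc21` in a functional assay on the whole organism (strain Swiss albino) for inhibition, with Mus musculus as the target, in the writhing test, with stated times of 60 min and 15 min, at a dose of 100 mg/kg by the oral route (on this read-out lower numbers stand for less inhibition and higher numbers for more inhibition at the one dose given (going by the name of the read-out)), gives 21.2%. Compound 2 `CCCNC(=O)CC1CCc2cc(OC)c(OC)cc21` gives 26.9%, the step of a number 5.7 percentage points higher from compound 1 to compound 2 (within the scatter) coming with ethyl in place of hydrogen on a saturated chain carbon bound to an amide-type nitrogen. Compound 3 `COc1cc2c(cc1OC)C(CC(=O)NCc1ccccc1)CC2` gives 48.1%; the step of a number 26.9 percentage points higher from compound 1 to compound 3 (beyond the scatter) comes with phenyl in place of hydrogen at that carbon, and a number 21.2 percentage points higher from compound 2 to compound 3 (beyond the scatter) with phenyl in place of ethyl there. Compound 3 thus stands highest of the three, beyond the scatter from both compound 2 and compound 1.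

Compound 4 `COc1cc2c(cc1OC)C(CC(=O)N1CCOCC1)CC2` differs from compound 3 by morpholin-4-yl in place of benzylamino on a carbonyl carbon. Among the measured compounds shown here, all three measured steps bear on the amide substituent, and the two that introduce phenyl were modest rises, but none replaces the whole benzylamino or closes a ring at the carbonyl carbon, so there is no direct precedent. Because the step of a number 21.2 percentage points higher from compound 2 to compound 3 (beyond the scatter) was a rise, taking the phenyl away in compound 4 is expected to give back part of it. Compound 4 is therefore expected to give 30%, within a range from 15% to 48%. The expected step is a number 18.1 percentage points lower from compound 3 to compound 4 (beyond the scatter).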

Compound 4, a percentage reported as inhibition, in the whole organism at one dose (the size of the read-out at that dose, not a potency): 23.6%
Compound 4: middle estimate off by 6.4 percentage points, on the high side, and the stated range covers the measured number.
By their numbers in this assay, from the lowest: compounds 1, 4 and 2 (each within the scatter of the next); then compound 3.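

In this assay the morpholin-4-yl amide shows that the level reached with benzylamino on the carbonyl carbon is lost when that whole group is replaced by this ring, which has no amide hydrogen, with a number 24.5 percentage points lower from compound 3 to compound 4 (beyond the scatter) as the result. Set against the two small amides, the same replacement gives a number 3.3 percentage points lower from compound 2 to compound 4 (within the scatter) for propylamino and a number 2.4 percentage points higher from compound 1 to compound 4 (within the scatter) for methylamino, so compound 4 cannot be told apart from compound 1 or compound 2, and among the four only compound 3 stands clear of the others. Nothing measured here explains why benzylamino stands apart.

The compounds shown leave open whether the phenyl ring or the amide hydrogen matters more, a question that cyclohexylmethylamino on the same carbonyl carbon would bear on. They also leave open how phenethylamino, with its longer chain to the phenyl, would compare with benzylamino.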